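The source may report more compounds than this note shows. Statements on the series, on what has been measured and on what is new or still open speak of the compounds shown alone.

Working notes on the amide series built on the shared core of compound 1 `CCOC(=O)c1sc(-c2cccc(NC(=O)c3ccc(F)cc3)c2)nc1Nc1ccc(N2CCN(C)CC2)cc1`. In a functional assay on Raji cells (Homo sapiens) for antiproliferative activity, read by CCK-8 assay, with a stated time of 72 h, tested at 40 uM (a higher number here means more inhibition at the concentration tested (going by the name of the read-out), a lower number less inhibition), compound 1 gives 16.8%, the second highest of the three numbers in hand. Compound 2 `CCOC(=O)c1sc(-c2cccc(NC(=O)c3ccc(C(C)(C)C)cc3)c2)nc1Nc1ccc(N2CCN(C)CC2)cc1` gives 4.22%, and compound 3 `CCOC(=O)c1sc(-c2cccc(NC(=O)c3ccc(C#N)cc3)c2)nc1Nc1ccc(N2CCN(C)CC2)cc1` gives 79.1%, the highest by a wide margin.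

The step to compound 4 `CCOC(=O)c1sc(-c2cccc(NC(=O)c3ccco3)c2)nc1Nc1ccc(N2CCN(C)CC2)cc1` changes the group on the carbonyl carbon: furan-2-yl in place of 4-fluorophenyl on a carbonyl carbon. Every measured step in the series also changes only the group on that carbonyl carbon, but each of them swaps one substituent on the same aromatic ring of carbon only, whereas here the whole ring is exchanged for a five-membered aromatic ring with 1 hetero atom. The measured steps show that this position is sensitive: a number 12.6 percentage points lower from compound 1 to compound 2 (beyond the scatter), a number 62.3 percentage points higher from compound 1 to compound 3 (beyond the scatter) and a number 74.9 percentage points higher from compound 2 to compound 3 (beyond the scatter). The large rise belongs to cyano alone; fluoro and tert-butyl both sit low. Nothing measured carries an oxygen-containing aromatic ring, so the direction of the step to compound 4 is open; a change of modest size, in either direction, is expected from compound 1 as a number 3.2 percentage points higher from compound 1 to compound 4 (within the scatter). For compound 4 the expected value is 20%, estimated to fall between 3% and 55%.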

Compound 4, a percentage reported as inhibition, at one concentration (the size of the read-out at that concentration, not a potency): 87.6%
Estimate against measurement, compound 4: 67.6 percentage points below, and the stated range ends below it.
By their numbers in this assay, from the lowest: compound 2; then compound 1; then compounds 3 and 4 (each within the scatter of the next).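

In this assay, exchanging the whole ring on the carbonyl carbon gives a number 70.8 percentage points higher from compound 1 to compound 4 (beyond the scatter) and a number 83.4 percentage points higher from compound 2 to compound 4 (beyond the scatter), so the high level no longer belongs to cyano alone and does not need a six-membered aromatic ring of carbon only. Furan-2-yl and 4-cyanophenyl cannot be told apart, with a number 8.5 percentage points higher from compound 3 to compound 4 (within the scatter), which means that two groups with quite different rings and atoms now share the top of the series, while 4-fluorophenyl and 4-(tert-butyl)phenyl stay low. No measurement at hand explains why these two groups sit together at the high level.

Still open, from the compounds shown here alone, is whether the rise goes with the oxygen of the furan-2-yl ring or with the five-membered ring itself: a thiophen-2-yl group, with sulfur in place of oxygen, and an unsubstituted phenyl group would help to separate the two. Also open, going by these compounds, is how compound 3 and compound 4 compare as potencies, as their numbers are percentages at a single concentration.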